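Cinnamamide series: methoxy pattern on the aryl group

This account rests on a few compounds, and the source may have more. Where it says the series, first, only, none or still open, it means among the compounds named here.

Measured compounds:
compound 1 `COc1ccc(/C=C/C(=O)Nc2cc3c(Nc4ccc(F)c(Cl)c4)ncnc3cc2OC)c(OC)c1` — 33300 nM
compound 2 `COc1cc(/C=C/C(=O)Nc2cc3c(Nc4ccc(F)c(Cl)c4)ncnc3cc2O[C@H]2CCOC2)cc(OC)c1O` — 27000 nM
compound 3 `COc1cc(/C=C/C(=O)Nc2cc3c(Nc4ccc(F)c(Cl)c4)ncnc3cc2O[C@H]2CCOC2)cc(OC)c1` — 10800 nM

The read-out is a functional assay on A549 cells (Homo sapiens) for cytotoxicity, read by MTT assay, with a stated time of 72 h; a higher number here means a weaker inhibitor, a lower number a stronger inhibitor. Compound 2 stands second highest of the three numbers; compound 1 is within the scatter of it, and compound 3 is the only one clearly apart, the difference being a 2.5-fold lower number from compound 2 to compound 3 (0.40 log units; beyond the scatter). Compound 1 and compound 3 differ in two places, so their values are only compared as numbers, with compound 3 the lower.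

The unmeasured compound 4 `COc1ccc(/C=C/C(=O)Nc2cc3c(Nc4ccc(F)c(Cl)c4)ncnc3cc2O[C@H]2CCOC2)c(OC)c1OC` differs from compound 2 in one place: 2,3,4-trimethoxyphenyl in place of 4-hydroxy-3,5-dimethoxyphenyl on a double-bonded chain carbon bound to a double-bonded chain carbon. Among the measured compounds shown here, the single step that bears on this is the one from compound 2 to compound 3, which removed the hydroxy group and gave a 2.5-fold lower number from compound 2 to compound 3 (0.40 log units; beyond the scatter). For the measured compounds named here, compound 4 likewise has no hydroxy, but its methoxy groups sit in a different arrangement, and no measured pair isolates that part of the change. A modest lowering of the number, of about the size seen for compound 3, is therefore expected, giving a 1.9-fold lower number from compound 2 to compound 4 (0.29 log units; within the scatter).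

Compound 4 is thus estimated at 14000 nM, within the range 6000 nM to 35000 nM.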

Compound 4, half-maximal inhibitory concentration: 70 nM
Compound 4: the middle estimate sits 200-fold (2.30 log units) above what was measured; the measured number lies below the stated range.
By their numbers in this assay, from the lowest: compound 4; then compound 3; then compounds 2 and 1 (each within the scatter of the next).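

In this assay, among the compounds shown here, the aryl group on this double-bonded chain carbon emerges as a site of very large change, not the modest one indicated by the earlier compounds: 2,3,4-trimethoxyphenyl in place of 4-hydroxy-3,5-dimethoxyphenyl gives a 390-fold lower number from compound 2 to compound 4 (2.59 log units; beyond the scatter), far more than a 2.5-fold lower number from compound 2 to compound 3 (0.40 log units; beyond the scatter) seen on replacing hydroxy with hydrogen. Loss of the hydroxy group therefore does not account for the full change, since 2,3,4-trimethoxyphenyl in place of 3,5-dimethoxyphenyl, with no hydroxy group on either side, still gives a 150-fold lower number from compound 3 to compound 4 (2.19 log units; beyond the scatter), so the methoxy pattern on the aryl group carries most of the effect within these compounds. No measurement shown here bears on the origin of this large change.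

The last step alters the number and the arrangement of the methoxy groups together, so the compounds shown do not separate these two contributions. As far as these compounds go, whether the low number in compound 4 depends on methoxy itself also stays open, as the series holds no aryl group in which an ethoxy group, a fluorine or an amine takes the place of one methoxy group.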